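A few compounds are considered here, and "the series" means these few. Any claim that something is new, unique, unknown or untested is made for them only; others in the source may bear on it.

Within the data shown here, compound 1, `COc1cc(-c2cc(/C=C/C(=O)c3ccc(N)cc3)[nH]n2)cc(OC)c1OC`, stands at the lower of the two numbers so far recorded in a functional assay on SK-MEL-5 cells (Homo sapiens) for inhibition, read by sulforhodamine B assay, with a stated time of 48 h (a higher number here means a weaker inhibitor of growth, a lower number a stronger inhibitor of growth), where compound 1 gives 1650 nM. Compound 2, `COc1ccc(-c2cc(/C=C/C(=O)c3ccc(OC)c(OC)c3)[nH]n2)cc1`, gives 1770 nM in this assay, and this gap lies within the scatter, so the two compounds are not separated by it. Compound 3, `COc1cc(-c2cc(/C=C/C(=O)c3ccc(Cl)c(Cl)c3)[nH]n2)cc(OC)c1OC`, has not been measured. Compared with compound 1 the change is as follows: 3,4-dichlorophenyl in place of 4-aminophenyl on a carbonyl carbon. Among the measured compounds shown here, no step between measured compounds mirrors this exchange, so the expectation for compound 3 rests on compound 1 and on the closeness of the two recorded numbers. The step of a 1.1-fold lower number from compound 1 to compound 3 (0.04 log units; within the scatter) is expected to be small and of no clear direction beyond the scatter, because compound 1 gives 1650 nM and compound 2 sits close to it. For compound 3 the estimated value in this assay is therefore 1500 nM, with a range from 500 nM to 4500 nM.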

Compound 3, concentration for 50% growth inhibition: 13400 nM
For compound 3 the middle estimate is 8.9-fold (0.95 log units) below the measured one; the measured number lies above the stated range.
By their numbers in this assay, from the lowest: compounds 1 and 2 (each within the scatter of the next); then compound 3.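

At the aryl group on the carbonyl carbon, the core of compound 1 does not tolerate every exchange: in this assay, 3,4-dichlorophenyl in place of 4-aminophenyl gives an 8.1-fold higher number from compound 1 to compound 3 (0.91 log units; beyond the scatter). Among these compounds, the earlier compounds offered no single-place step, so this is the first sign that the group at this place can move the number beyond the scatter. The exchange removes the hydrogen-bond donor and acceptor counted on 4-aminophenyl and adds two chlorine atoms, and no measurement shown accounts for the weaker growth inhibition.

As far as these compounds go, this single step joins the loss of the amine and the arrival of the chlorines, so their separate contributions remain unknown. It also leaves open how unsubstituted phenyl, a hydroxyl, a methoxy or an acetamide would fare at this place.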